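The compounds below may be only part of what the source reports. "The series", "measured", "known", "first", "only" and "open" are said of these compounds alone.

Measured compounds in an ADME assay on microsomes from liver (Homo sapiens) for metabolic stability, read by LC-MS, using NADPH, tested at 5 uM; on this read-out lower numbers stand for a shorter-lived compound and higher numbers for a longer-lived compound:
compound 1, `NS(=O)(=O)c1cc(-c2nnc(CN3CCN(c4ccccc4)CC3)o2)c(Cl)cc1SCc1ccccc1`, gives 0.33 h
compound 2, `NS(=O)(=O)c1cc(-c2nnc(CN3CCN(c4ccc(Cl)cc4)CC3)o2)c(Cl)cc1SCc1ccccc1`, gives 0.455 h
compound 3, `NS(=O)(=O)c1cc(-c2nnc(/C=C/c3ccccc3)o2)c(Cl)cc1SCc1ccccc1`, gives 0.228 h

Compound 4, `NS(=O)(=O)c1cc(-c2nnc(/C=C/c3cccc(Cl)c3)o2)c(Cl)cc1SCc1ccccc1`, has not yet been measured in this assay.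

Compound 1 and compound 2 share one core and differ by chloro in place of hydrogen on an aromatic carbon. This change made a step of a 1.4-fold higher number from compound 1 to compound 2 (0.14 log units; within the scatter) in this assay. Compound 3 carries a different core; the difference between the two cores is not broken down here. Compound 3 against compound 1 and compound 2 can be compared only by the values themselves, and all three lie within the usual scatter of one another, so no order among them is claimed.

Compound 4 differs from compound 3 by chloro in place of hydrogen on an aromatic carbon. For the measured compounds named here, this is the same kind of change as the one from compound 1 to compound 2, not the same change: in compound 2 the chloro sits para to a large group, whereas in compound 4 it sits meta to a large group.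

Compound 4 is expected to show a step of a 1.3-fold higher number from compound 3 to compound 4 (0.12 log units; within the scatter) in this assay. This expectation rests on the only measured occurrence of the change, a 1.4-fold higher number from compound 1 to compound 2 (0.14 log units; within the scatter), which stayed within the scatter, and on the closeness of all three measured values. Compound 4 is therefore estimated at 0.3 h, with a range from 0.18 h to 0.5 h.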

Compound 4, half-life: 0.352 h
The estimate for compound 4 lay 1.2-fold (0.07 log units) below the measured number, and the stated range covers the measured number.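

In this assay, chloro in place of hydrogen on an aromatic carbon gave a 1.5-fold higher number from compound 3 to compound 4 (0.19 log units; within the scatter), and the two occurrences of this change on different cores do not differ: the same change on two cores in this assay, a 1.4-fold higher number (0.14 log units; within the scatter) from compound 1 to compound 2 and a 1.5-fold higher number (0.19 log units; within the scatter) from compound 3 to compound 4, 1.1-fold (0.05 log units) apart, within the scatter of two such steps. On these two cores the change therefore behaves alike, with neither step leaving the scatter, even though the chloro does not sit in the same place in the two pairs, being meta to a large group in compound 4. Since both steps stay within the scatter, they do not show that chloro truly lengthens the half-life, and two pairs give no rule for other cores or other places on the ring.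

On these data alone, it remains open whether a group other than chloro on the same aromatic ring, such as a methoxy, a nitrile or an amine, would give a step beyond the scatter. Also open, as far as these compounds go, is how the half-life would respond to a carboxylic acid on that ring or to a longer chain in place of the 2-phenylethenyl group of compound 3.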